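Swapping a methyl for ethoxy on the anilino ring

This account rests on a few compounds, and the source may have more. Where it says the series, first, only, none or still open, it means among the compounds named here.

Of the compounds shown here, two of one series have been tested so far. Compound 1 `O=C(C1=C(O)C(=O)N(CCCn2ccnc2)C1c1ccc(Br)cc1)c1ccccc1` carries a hydroxy group on the shared core, and in a functional assay on A549 cells (Homo sapiens) for antiproliferative activity, read by MTT assay, with a stated time of 72 h (a higher number here means a weaker inhibitor, a lower number a stronger inhibitor), compound 1 gives 73100 nM. Compound 2 `Cc1ccc(NC2=C(C(=O)c3ccccc3)C(c3ccc(Br)cc3)N(CCCn3ccnc3)C2=O)cc1` instead carries a (4-methylphenyl)amino group there, and in this assay compound 2 gives 29400 nM. That single exchange produced a 2.5-fold lower number from compound 1 to compound 2 (0.40 log units; beyond the scatter), so compound 2 holds the lower of the two numbers.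

Compound 3 `CCOc1ccc(NC2=C(C(=O)c3ccccc3)C(c3ccc(Br)cc3)N(CCCn3ccnc3)C2=O)cc1` keeps everything of compound 2 and changes only (ethoxy in place of methyl on an aromatic carbon). Among the compounds with values here, none of the measured steps touches this part of the molecule: the one known step concerns the group on the core, not a substituent on the outer ring. There is therefore no measured basis for a direction, and a step of a 1.1-fold lower number from compound 2 to compound 3 (0.05 log units; within the scatter) is expected, within the usual scatter. Compound 3 is estimated to give 26000 nM in this assay, with a range from 9000 nM to 75000 nM.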

Compound 3, half-maximal inhibitory concentration: 20200 nM
For compound 3 the middle estimate is 1.3-fold (0.11 log units) above the measured one; the measured number falls inside the stated range.
By their numbers in this assay, from the lowest: compounds 3 and 2 (each within the scatter of the next); then compound 1.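

Exchanging methyl for ethoxy on the aromatic carbon para to a large group gives a 1.5-fold lower number from compound 2 to compound 3 (0.16 log units; within the scatter) in this assay and so shows that this outer-ring position can take ethoxy, with its hydrogen-bond acceptor, without a change that stands out from the scatter. Replacing hydroxy on the shared core with the (4-ethoxyphenyl)amino group gives a 3.6-fold lower number from compound 1 to compound 3 (0.56 log units; beyond the scatter) and so shows that the step beyond the scatter is not confined to the (4-methylphenyl)amino group. Nothing available explains these numbers.

Going by these compounds, whether a primary amine, a carboxylic acid or a longer chain such as butoxy at this carbon would move the number beyond the scatter remains open. So does the effect of placing ethoxy on another carbon of the same ring.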